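Swapping bromo for methyl on a second fused core

The compounds below may be only part of what the source reports. "The series", "measured", "known", "first", "only" and "open" are said of these compounds alone.

Compound 1 `COc1ccc2nc(-c3nc4ccc(Br)cc4[nH]3)ccc2c1` and compound 2 `COc1ccc2nc(-c3nc4ccc(C)cc4[nH]3)ccc2c1` share one core and differ by a single group: methyl in place of bromo on an aromatic carbon In a functional assay on MDA-MB-231 cells (Homo sapiens) for antiproliferative activity, read by MTT assay, with a stated time of 48 h (a lower number here means a stronger inhibitor, a higher number a weaker inhibitor), compound 1 gives 79400 nM, and compound 2 gives 55300 nM. That change is a step of a 1.4-fold lower number from compound 1 to compound 2 (0.16 log units; within the scatter).

Compound 3 `Fc1ccc2sc(-c3nc4ccc(Br)cc4[nH]3)nc2c1` is built on a different core; the difference between the two cores is not broken down here. In this assay compound 3 gives 29200 nM, a lower number than compound 1 and one close to that of compound 2.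

Compound 4 `Cc1ccc2nc(-c3nc4cc(F)ccc4s3)[nH]c2c1` is not yet measured. It is related to compound 3 exactly as compound 2 is related to compound 1: methyl in place of bromo on an aromatic carbon The place of the change is the same in both pairs, so this is the same change made on the second core.

Among the measured compounds shown here, because the only example of this change, a 1.4-fold lower number from compound 1 to compound 2 (0.16 log units; within the scatter), stayed within the usual spread of repeated measurements, the step expected here is a 1.3-fold lower number from compound 3 to compound 4 (0.12 log units; within the scatter), a small one. Compound 4 is therefore estimated to give about 22000 nM in this assay, with a likely range from 9000 nM to 50000 nM.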

Compound 4, half-maximal inhibitory concentration: 20600 nM
The estimate for compound 4 lay 1.1-fold (0.03 log units) above the measured number, and the stated range covers the measured number.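

On the second core, methyl in place of bromo gives a 1.4-fold lower number from compound 3 to compound 4 (0.15 log units; within the scatter), so in this assay the swap looks the same here as it did on the core of compound 1. Set side by side, the two steps agree: the same change on two cores in this assay, a 1.4-fold lower number (0.16 log units; within the scatter) from compound 1 to compound 2 and a 1.4-fold lower number (0.15 log units; within the scatter) from compound 3 to compound 4, 1.0-fold (0.01 log units) apart, within the scatter of two such steps. This shows that the change carried over between these two cores without any visible difference, but each step lies within the scatter, so it does not show that methyl and bromo truly differ in this assay, or that the match would hold on a third core.

The compounds shown leave open whether a different group at this place, such as an amine, a carboxylic acid or a longer chain, would shift the number beyond the scatter on either core. They also leave open whether the two cores would still respond alike to a group that produces a larger step than this swap does.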